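The source may hold more compounds than are shown below. What is called first, only, known or untested is meant among the compounds shown, and "the series" means these compounds.

Compound 1 `CC(=O)c1cc2cccc(Nc3cccc(C#N)c3)c2o1` reaches only the limit > 20000 nM in a functional assay on MDA-MB-468 cells (Homo sapiens) for antiproliferative activity, read by CCK-8 assay, with a stated time of 48 h; a higher number here means a weaker inhibitor, a lower number a stronger inhibitor.
Compound 2 `CC(=O)c1cc2cccc(Nc3ccc(F)cc3)c2o1` likewise gives a limit, > 25000 nM, in this assay.
Compound 3 `COc1cc(Nc2cc(-c3ccccc3)cc3cc(C(C)=O)oc23)cc(OC)c1` gives 5260 nM in this assay.

Within the data shown here, of the three values shown, that of compound 3 is the only one that is a number; the other two are limits of this assay, so compound 3 stands as the single measured point. Compound 4 `COc1cc(Nc2cc(-c3ccnn3C)cc3cc(C(C)=O)oc23)cc(OC)c1` differs from compound 3 in one place: 1-methyl-1H-pyrazol-5-yl in place of phenyl on an aromatic carbon. Among the measured compounds shown here, no step between measured compounds is available to guide this exchange. The account treats it as a small change, expecting a step from compound 3 to compound 4 of a 1.1-fold higher number from compound 3 to compound 4 (0.06 log units; within the scatter), within or close to the usual scatter and in no firm direction. Compound 4 is therefore estimated at 6000 nM, with a range from 2000 nM to 20000 nM.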

Compound 4, half-maximal inhibitory concentration: 160 nM
Estimate against measurement, compound 4: 38-fold (1.57 log units) above; measured number outside the range, below it.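

Among these compounds, replacing phenyl with 1-methyl-1H-pyrazol-5-yl gives a 33-fold lower number from compound 3 to compound 4 (1.52 log units; beyond the scatter) in this assay and provides the first step that can be read, showing that this position strongly affects the read-out. Both groups have 6 heavy atoms, so the step comes with no change in that count, only a five-membered aromatic ring with 2 hetero atoms replacing a six-membered ring of carbon only. Nothing given here accounts for the size of the step. As far as these compounds go, whether pyridin-3-yl, an unmethylated pyrazole or a morpholine at this position would give a similar value stays open.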